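Replacing Bromo with 2-Hydroxyphenyl on Compound 1

The compounds below may be only part of what the source reports. "The series", "measured", "known", "first", "only" and "open" are said of these compounds alone.

Compound 1 `Nc1ccc(S(=O)(=O)N2CCN(c3ncc(C(O)(C(F)(F)F)C(F)(F)F)cc3Br)CC2)cn1` is the starting point. In an ADME assay (liver) for metabolic stability, with Liver microsome (Rattus norvegicus) as the target, using microsomes and NADPH, with a stated time of 30 min, tested at 1 uM (a lower number here means slower removal, a higher number faster removal of the compound), compound 1 gives 32 mL.min-1.g-1, the lowest of the three numbers recorded. Compound 2 `Nc1ccc(S(=O)(=O)N2CCN(c3ncc(C(O)(C(F)(F)F)C(F)(F)F)cc3C#CC3CC3)CC2)cn1` gives 67 mL.min-1.g-1 in this assay, and compound 3 `CC(C)(C)n1cc(-c2cc(C(O)(C(F)(F)F)C(F)(F)F)cnc2N2CCN(S(=O)(=O)c3ccc(N)nc3)CC2)cn1` gives 459 mL.min-1.g-1 in this assay. The step of a 2.1-fold higher number from compound 1 to compound 2 (0.32 log units; beyond the scatter) is modest, whereas a 14-fold higher number from compound 1 to compound 3 (1.16 log units; beyond the scatter) is large, and a 6.9-fold higher number from compound 2 to compound 3 (0.84 log units; beyond the scatter) separates those two replacements of the bromo group.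

Compound 4 `Nc1ccc(S(=O)(=O)N2CCN(c3ncc(C(O)(C(F)(F)F)C(F)(F)F)cc3-c3ccccc3O)CC2)cn1` carries a different replacement at the same aromatic carbon: 2-hydroxyphenyl in place of bromo on an aromatic carbon. Both measured replacements of bromo at that position gave higher numbers in this assay, and the larger of the two came from entering an aromatic ring, as in compound 3 with a 14-fold higher number from compound 1 to compound 3 (1.16 log units; beyond the scatter). The 2-hydroxyphenyl group of compound 4 likewise brings in a six-membered aromatic ring, so a rise beyond the scatter is expected, with a size estimated between the two measured steps, as a 4.1-fold higher number from compound 1 to compound 4 (0.61 log units; beyond the scatter). For compound 4 the estimate in this assay is 130 mL.min-1.g-1, expected to lie between 45 mL.min-1.g-1 and 380 mL.min-1.g-1.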

Compound 4, intrinsic clearance in microsomes: 125 mL.min-1.g-1
Estimate against measurement, compound 4: 1.0-fold (0.02 log units) above; measured number inside the range.
By their numbers in this assay, from the lowest: compound 1; then compounds 2 and 4 (each within the scatter of the next); then compound 3.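

In this assay, an aromatic ring entering at this position does not by itself bring the full rise seen with the 1-(tert-butyl)-1H-pyrazol-4-yl group: 2-hydroxyphenyl gives a 3.9-fold higher number from compound 1 to compound 4 (0.59 log units; beyond the scatter), but also a 3.7-fold lower number from compound 3 to compound 4 (0.56 log units; beyond the scatter). A ring is also not what separates 2-hydroxyphenyl from the ringless-at-the-link 2-cyclopropylethynyl group, as the two cannot be told apart, with a 1.9-fold higher number from compound 2 to compound 4 (0.27 log units; within the scatter). All three replacements of bromo give higher numbers than compound 1, and nothing available explains the differences among them.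

On these data alone, it remains open whether the hydroxyl of compound 4 matters, as a plain phenyl or a methoxyphenyl group would show. Also open, as far as these compounds go, is whether a small group at this aromatic carbon, such as a nitrile or an amine, would stay close to compound 1.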